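A few compounds are considered here, and "the series" means these few. Any claim that something is new, unique, unknown or untested is made for them only; others in the source may bear on it.

Measured so far in a functional assay on KG-1 cells (Homo sapiens) for cytotoxicity, read by luminescence and CellTiter-Glo, with a stated time of 3 days; on this read-out lower numbers stand for stronger inhibition and higher numbers for weaker inhibition
- Compound 1 `O=C(Nc1ccc(Cl)cc1Cl)c1cc(F)ccc1O` gives 850 nM
- Compound 2 `O=C(Nc1ccc([N+](=O)[O-])cc1)c1cc(F)ccc1O` gives 1100 nM

Compound 2, at 1100 nM, stands level with compound 1, at 850 nM, within the usual scatter of repeated measurements, so these numbers cannot rank the two. Two compounds also cannot show a trend.

Compound 3 `O=C(Nc1ccc([N+](=O)[O-])cc1Cl)c1cc(F)ccc1O` comes from compound 2 by a single change (chloro in place of hydrogen on an aromatic carbon). Chloro takes the place of hydrogen on an aromatic carbon, ortho to a large group and meta to a nitro group. Going by the values given here, no measured pair shows this change alone. Compound 1 has chloro at the same place but differs from compound 2 elsewhere too, and compound 1, at 850 nM, gives no hint of a large swing. A modest move toward a lower number, meaning stronger inhibition, is therefore expected in this assay and may prove no larger than the scatter. The estimate is a 2.2-fold lower number from compound 2 to compound 3 (0.34 log units; beyond the scatter) on this expected course. For compound 3 the estimated value is 500 nM with an expected range from 200 nM to 1200 nM for a single measurement.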

Compound 3, half-maximal inhibitory concentration: 490 nM
Beside the measured number, compound 3's estimate is 1.0-fold (0.01 log units) above it, and the stated range covers the measured number.
By their numbers in this assay, from the lowest: compounds 3, 1 and 2 (each within the scatter of the next, the first and the last beyond it).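

In this assay, chloro in place of hydrogen on an aromatic carbon, ortho to a large group and meta to a nitro group, gives a 2.2-fold lower number from compound 2 to compound 3 (0.35 log units; beyond the scatter). Going by these compounds alone, this is the first pair that shows this change alone, and the step is modest but lies beyond the scatter, though it rests on this one pair. With that chloro kept, nitro in place of chloro on an aromatic carbon gives a 1.7-fold lower number from compound 1 to compound 3 (0.24 log units; within the scatter), which lies within the scatter, so this pair cannot be ranked and the two groups stand level at that place. Nothing measured here offers an explanation for the chloro step.

The compounds shown leave open whether this step belongs to chloro alone or would also appear with fluoro, bromo, methyl or an amine on the same aromatic carbon. They also leave open whether chloro would give a similar step with a nitrile or a carboxylic acid in the place of the nitro group.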